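Methoxy for fluoro on the nitrogen-linked phenyl ring

The source may report more compounds than this note shows. Statements on the series, on what has been measured and on what is new or still open speak of the compounds shown alone.

Measured compounds:
- compound 1 `O=C(Nc1ccc(Oc2ccnc3[nH]ccc23)cc1)c1cn(-c2ccccc2)c2ccccc2c1=O` gives 3560 nM in a functional assay on MCF7 cells (Homo sapiens) for inhibition, read by MTT assay, with a stated time of 72 h; on this read-out lower numbers stand for stronger inhibition and higher numbers for weaker inhibition
- compound 2 `O=C(Nc1ccc(Oc2ccnc3[nH]ccc23)cc1)c1cn(-c2ccc(C(F)(F)F)cc2Cl)c2ccccc2c1=O` gives 3570 nM in this assay
- compound 3 `Cn1ccc2c(Oc3ccc(NC(=O)c4cn(-c5ccc(F)cc5)c5ccccc5c4=O)cc3F)ccnc21` gives "not determined" (no result reported) in this assay, that is, no number is reported for it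

Compound 3 therefore has no place on the scale set by compounds 1 and 2; its result in this assay is simply not available, so nothing can be said about where it stands relative to them.

Compound 4 `COc1ccc(-n2cc(C(=O)Nc3ccc(Oc4ccnc5c4ccn5C)c(F)c3)c(=O)c3ccccc32)cc1` differs from compound 3 in one spot: methoxy in place of fluoro on an aromatic carbon. For the measured compounds named here, the only measured step that touches the same part of the shared core is the one on the phenyl ring attached to the aromatic nitrogen, a 1.0-fold higher number from compound 1 to compound 2 (0.00 log units; within the scatter), where a much larger change of substituents on that ring left the number unchanged within the scatter. On that basis a swap of fluoro for methoxy on the same ring is expected to produce no step beyond the scatter in this assay, in either direction. With compound 3 unmeasured, the anchor can only be the numbers for compounds 1 and 2, and compound 4 is estimated at 3500 nM, with a range from 800 nM to 15000 nM to reflect that uncertainty.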

Compound 4, half-maximal inhibitory concentration: 6720 nM
For compound 4 the middle estimate is 1.9-fold (0.28 log units) below the measured one, within the range that was stated.
By their numbers in this assay, from the lowest: compounds 1, 2 and 4 (each within the scatter of the next).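

With no number for compound 3 in this assay to set against compound 4, no new step can be read. The compounds shown leave open what the change from 4-fluorophenyl to 4-methoxyphenyl does to this read-out. No supporting evidence bears on the result.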